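Replacing 4-methoxyphenyl with thiophen-3-yl

This account rests on a few compounds, and the source may have more. Where it says the series, first, only, none or still open, it means among the compounds named here.

In a functional assay on MGC-803 cells (Homo sapiens) for antiproliferative activity, read by CellTiter-Glo, with a stated time of 72 h (on this read-out lower numbers stand for stronger inhibition and higher numbers for weaker inhibition), compound 1 `O=C(NO)c1ccc(/C=C/c2ccnc(-c3ccccc3O)c2)cc1` gives 1420 nM, while compound 3 `COc1ccc(-c2cc(/C=C/c3ccc(C(=O)NO)cc3)ccn2)cc1` gives 3510 nM, the higher of the two exact numbers. For compound 2 `O=C(NO)c1ccc(/C=C/c2ccnc(-c3ccc(F)cc3)c2)cc1`, the result is a limit of the assay, > 10000 nM.

Compound 4 `O=C(NO)c1ccc(/C=C/c2ccnc(-c3ccsc3)c2)cc1` has thiophen-3-yl in place of 4-methoxyphenyl on an aromatic carbon. Changing the group at this place has already moved the read-out beyond the scatter: a 2.5-fold higher number from compound 1 to compound 3 (0.39 log units; beyond the scatter), an at least 2.8-fold lower number from compound 2 to compound 3 (0.45 log units; beyond the scatter) and an at least 7.0-fold higher number from compound 1 to compound 2 (0.84 log units; beyond the scatter). For the measured compounds named here, none of these steps involves thiophen-3-yl, so they suggest no direction, only that the group matters. The expected change is a 1.2-fold lower number from compound 3 to compound 4 (0.07 log units; within the scatter), which would lie within the scatter. Compound 4 is estimated at 3000 nM, with an expected range of 1000 nM to 9000 nM.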

Compound 4, half-maximal inhibitory concentration: 3680 nM
For compound 4 the middle estimate is 1.2-fold (0.09 log units) below the measured one, within the range that was stated.
By their numbers in this assay, from the lowest: compound 1; then compounds 3 and 4 (each within the scatter of the next). At a limit, above all of these: compound 2.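

Although thiophen-3-yl is a five-membered ring with fewer heavy atoms than 4-methoxyphenyl, the swap leaves the read-out unchanged within the scatter, with a 1.0-fold higher number from compound 3 to compound 4 (0.02 log units; within the scatter). The 2-hydroxyphenyl group of compound 1 still gives the lower number, with a 2.6-fold higher number from compound 1 to compound 4 (0.41 log units; beyond the scatter). Thiophen-3-yl also differs from 4-fluorophenyl, with an at least 2.7-fold lower number from compound 2 to compound 4 (0.43 log units; beyond the scatter), but that step starts from a limit for compound 2, not an exact number: the limit of > 10000 nM in this assay, at which 1 of the 4 values shown sits.

On these data alone, it remains open whether a five-membered ring can reach the level of compound 1. Also open, as far as these compounds go, is how a phenyl ring carrying an amine or a carboxylic acid would read at this place.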